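The source may report more compounds than this note shows. Statements on the series, on what has been measured and on what is new or still open speak of the compounds shown alone.

Measured compounds:
- compound 1 `Cn1ncc(Cl)c1-c1cc(C(=O)N[C@@H]2CN[C@H](CCN3CCC(O)CC3)C[C@H]2c2ccc(Cl)c(Cl)c2)oc1Cl` — in an assay for inhibition of RAC-alpha serine/threonine-protein kinase (Homo sapiens), read by HTRF, with a stated time of 1 h (a lower number here means a stronger inhibitor, a higher number a weaker inhibitor), compound 1 gives 5.99 nM
- compound 2 `CCC[C@@H]1C[C@@H](c2ccc(Cl)c(Cl)c2)[C@H](NC(=O)c2cc(-c3c(Cl)cnn3C)c(Cl)o2)CN1` — in this assay compound 2 gives 10.4 nM
- compound 3 `Cn1ncc(Cl)c1-c1cc(C(=O)N[C@@H]2CN[C@H](CCO)C[C@H]2c2ccc(Cl)c(Cl)c2)oc1Cl` — in this assay compound 3 gives 2.74 nM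

Compound 3 stands lowest of the three numbers, and both of its steps are beyond the scatter: a 2.2-fold lower number from compound 1 to compound 3 (0.34 log units; beyond the scatter) and a 3.8-fold lower number from compound 2 to compound 3 (0.58 log units; beyond the scatter). The step between the other two, a 1.7-fold higher number from compound 1 to compound 2 (0.24 log units; within the scatter), lies within the scatter. On these three numbers compound 3 is therefore the strongest inhibitor of the set.

Compound 4 `COCC[C@@H]1C[C@@H](c2ccc(Cl)c(Cl)c2)[C@H](NC(=O)c2cc(-c3c(Cl)cnn3C)c(Cl)o2)CN1` differs from compound 3 in one place: methyl in place of hydrogen on an oxygen on a saturated carbon. Among the compounds with values here, no measured pair shows exactly this change. The nearest guides are the steps that end at compound 3, which replace the hydroxy by a methyl or by a 4-hydroxypiperidin-1-yl group on the same chain carbon, and in both directions the hydroxy gave the lower number. Methylating the oxygen removes the hydroxy as a donor while keeping the oxygen, so compound 4 is expected to sit between compound 3 and compound 2 rather than below compound 3. A modest rise is expected, a 2.0-fold higher number from compound 3 to compound 4 (0.30 log units; within the scatter), and compound 4 is estimated at 5.5 nM, with a range from 2.5 nM to 12 nM.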

Compound 4, half-maximal inhibitory concentration: 7.01 nM
Estimate against measurement, compound 4: 1.3-fold (0.11 log units) below; the range from low to high includes it.
By their numbers in this assay, from the lowest: compound 3; then compounds 1, 4 and 2 (each within the scatter of the next).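

In this assay, the change from 2-hydroxyethyl to 2-methoxyethyl gives a 2.6-fold higher number from compound 3 to compound 4 (0.41 log units; beyond the scatter), so methyl in place of hydrogen on this oxygen is enough to raise the number even though the oxygen stays in the side chain. The earlier steps replaced the whole hydroxy group, whereas this one separates the hydrogen from the oxygen: with a 1.5-fold lower number from compound 2 to compound 4 (0.17 log units; within the scatter) and a 1.2-fold higher number from compound 1 to compound 4 (0.07 log units; within the scatter) both within the scatter, the methoxy compound does not separate from compound 2, which has no oxygen in the side chain, or from compound 1, which has a hydroxy further out on its 4-hydroxypiperidin-1-yl group, so among these four compounds the clear advantage belongs to the 2-hydroxyethyl chain of compound 3 alone, and compound 1 shows that a hydroxy somewhere in the side chain does not by itself secure it. No measurement is at hand that explains this rise.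

The compounds shown leave open whether a primary amine or a carboxylic acid at the end of this chain would match the number of compound 3. They also leave open how a hydroxymethyl group or a longer chain ending in hydroxy would read in this assay.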